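Amide replacement on an azetidine carbonyl: pyrrolidine to piperidine

The source may report more compounds than this note shows. Statements on the series, on what has been measured and on what is new or still open speak of the compounds shown alone.

Compound 1 `O=C(c1ccc(F)cc1)N1CC(c2nc(-c3cccc(Cl)c3)no2)C1`: 4000 nM
Compound 2 `CC1CCN(C(=O)N2CC(c3nc(-c4cccc(Cl)c4)no3)C2)C1`: > 10000 nM

In an assay on HEK293 cells for negative allosteric modulation of metabotropic glutamate receptor 5 (Homo sapiens), read by FLIPR (a lower number here means a stronger inhibitor, a higher number a weaker inhibitor), compound 1 gives 4000 nM. Compound 2 reaches only the limit of the assay, > 10000 nM, so only a bound is known for it (the limit of > 10000 nM in this assay, at which 1 of the 2 values shown sits). Going by the values given here, the step of an at least 2.5-fold higher number from compound 1 to compound 2 (0.39 log units; beyond the scatter) is the single measured change here. Compound 3 `CC1CCN(C(=O)N2CC(c3nc(-c4cccc(Cl)c4)no3)C2)CC1` differs from compound 2 by 4-methylpiperidin-1-yl in place of 3-methylpyrrolidin-1-yl on a carbonyl carbon. Among the compounds with values here, no measured step covers a ring enlargement of this kind, so the expectation rests on compound 2 alone: compound 3 is expected to stay near its limit, with an estimated step that the limit leaves unreadable from compound 2 to compound 3. Compound 3 is estimated at 15000 nM, between 6000 nM and 40000 nM.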

Compound 3, half-maximal inhibitory concentration: > 10000 nM
Compound 3 gave a limit, no number (the forecaster's own chance of this, stated with the estimate: 70%); the middle value is on the limit's open side.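

In this assay, compound 3 also ends in a limit, > 10000 nM, and not a number. With 4-methylpiperidin-1-yl in place of 4-fluorophenyl on the carbonyl carbon, the result is an at least 2.5-fold higher number from compound 1 to compound 3 (0.39 log units; beyond the scatter), so the loss seen with 3-methylpyrrolidin-1-yl also appears with a second, larger ring. The step between the two rings cannot be read, and neither can be ranked against the other: the limit of > 10000 nM in this assay, at which 2 of the 3 values shown sit.

Still open, on these data alone, is whether a plain piperidine without the methyl group, or a morpholine, on this carbonyl carbon would give a number at all. Also open, as far as these compounds go, is whether any other aryl group there would improve on compound 1.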